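Replacing the 4-fluorophenyl on an aromatic nitrogen

The source may hold more compounds than are shown below. What is called first, only, known or untested is meant among the compounds shown, and "the series" means these compounds.

Measured compounds:
compound 1 `CN(CCNCc1cn(-c2ccc(F)cc2)nn1)CCNc1ccnc2cc(Cl)ccc12` — 19000 nM
compound 2 `CN(CCNCc1cn(CC(=O)O)nn1)CCNc1ccnc2cc(Cl)ccc12` — > 200000 nM (a limit of the assay, not a number)

Within the data shown here, compound 1 holds the only measured number in a functional assay on HCC827 cells (Homo sapiens) for antiproliferative activity, read by sulforhodamine B assay, with a stated time of 72 h; on this read-out higher numbers stand for weaker inhibition and lower numbers for stronger inhibition; compound 1 gives 19000 nM. For compound 2 in this assay only a limit is reported, namely > 200000 nM. Among the measured compounds shown here, the one measured step at this place is an at least 10-fold higher number from compound 1 to compound 2 (1.02 log units; beyond the scatter), and it ran into (the limit of > 200000 nM in this assay, at which 1 of the 2 values shown sits). Compound 3 `CN(CCNCc1cn(CCCO)nn1)CCNc1ccnc2cc(Cl)ccc12` differs from compound 1 in 3-hydroxypropyl in place of 4-fluorophenyl on an aromatic nitrogen. For the measured compounds named here, because the same 4-fluorophenyl leaves in the step of an at least 10-fold higher number from compound 1 to compound 2 (1.02 log units; beyond the scatter), that step is the one that bears on compound 3, and a step in the same weakening direction is expected in this assay, though its size is uncertain since the new group is not carboxymethyl. Compound 3 is therefore expected to give 60000 nM, between 20000 nM and 200000 nM. The expected step is a 3.2-fold higher number from compound 1 to compound 3 (0.50 log units; beyond the scatter).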

Compound 3, half-maximal inhibitory concentration: > 200000 nM
Compound 3: only a limit was reported; the forecaster's own chance of this, stated with the estimate: 30%; middle value at least 3.3-fold (0.52 log units) away from the limit.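

In this assay, 3-hydroxypropyl on this aromatic nitrogen gives an at least 10-fold higher number from compound 1 to compound 3 (1.02 log units; beyond the scatter), so the loss seen with carboxymethyl is not confined to that one group. Of the three compounds, only compound 1, whose group holds a six-membered aromatic ring of carbon only, gives a measured number rather than a limit. Compound 2 and compound 3 cannot be ordered, and the step between them cannot be read, because both values are limits: the limit of > 200000 nM in this assay, at which 2 of the 3 values shown sit.

Going by these compounds, it remains open whether the fluorine or the aromatic ring of the 4-fluorophenyl goes with the measured number, which a plain phenyl or a benzyl group would help to separate. On these data alone, it is also open whether a longer alkyl chain without the hydroxyl, or a propyl chain ending in an amine, would give a measured number in this assay.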